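Trimming compound 1 down to a cyclopropyl group

This account rests on a few compounds, and the source may have more. Where it says the series, first, only, none or still open, it means among the compounds named here.

Measured in an ADME assay for permeability, using PAMPA, at pH 5.5; a lower number here means that the compound crosses the layer more slowly, a higher number that the compound crosses the layer faster:
- compound 1 `CCCCc1nc(=O)c(S(=O)(=O)c2ccc(-c3ccnc(NC(=O)C4CC4)c3)cc2)c(O)n1-c1c(OC)cccc1OC`: 183 nm/s
- compound 2 `CCCCc1[nH]c(=O)c(S(=O)(=O)c2ccc(-c3ccc(F)cc3)cc2)c(O)c1-c1c(OC)cccc1OC`: "not determined" (no result reported)
- compound 3 `CCCCc1[nH]c(=O)c(S(=O)(=O)c2ccc(-n3ccccc3=O)cc2)c(O)c1-c1c(OC)cccc1OC`: 177 nm/s

Only two of these compounds have a number to compare. Compound 1 at 183 nm/s and compound 3 at 177 nm/s lie within the scatter of each other, so repeat measurements could not tell them apart. Compound 2 gives no number to set beside them.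

The next compound to be tested is compound 4 `CCCCc1nc(=O)c(S(=O)(=O)c2ccc(C3CC3)cc2)c(O)n1-c1c(OC)cccc1OC`. It keeps the core of compound 1 but has cyclopropyl in place of 2-((cyclopropylcarbonyl)amino)pyridin-4-yl on an aromatic carbon, para to a large group: cyclopropyl in place of 2-((cyclopropylcarbonyl)amino)pyridin-4-yl on an aromatic carbon. This swap removes most of that substituent.

Among the measured compounds shown here, no pair of measured compounds differs in just one place, so no measured step shows what a swap like this does in this assay. Any forecast is therefore a judgement with a wide margin. The direction expected is upward, by a step of moderate size, though no change beyond the scatter remains possible. The estimated change is a 2.2-fold higher number from compound 1 to compound 4 (0.34 log units; beyond the scatter). Compound 4 is expected at 400 nm/s, with an estimated range of 150 nm/s to 900 nm/s.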

Compound 4, apparent permeability: 615 nm/s
Estimate against measurement, compound 4: 1.5-fold (0.19 log units) below; the range from low to high includes it.
By their numbers in this assay, from the lowest: compounds 3 and 1 (each within the scatter of the next); then compound 4.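

Among the compounds shown here, this is the first step in this assay that changes one place only, and it shows that the read-out responds to what sits on this aromatic carbon: cyclopropyl in place of 2-((cyclopropylcarbonyl)amino)pyridin-4-yl gives a 3.4-fold higher number from compound 1 to compound 4 (0.53 log units; beyond the scatter), a change larger than repeat measurements would produce. The swap takes away the six-membered aromatic ring with its hetero atom, the amide link with its hydrogen-bond donor and acceptors, and most of the heavy atoms of the old substituent at once, so this single step cannot show which of these parts accounts for the rise. No measured property of these compounds is available to explain the change.

Groups between the two extremes remain open: a plain phenyl or an unacylated 2-aminopyridin-4-yl on the same carbon would help separate the effect of the aromatic ring from that of the amide, while a morpholine or a carboxylic acid there would test quite different atoms. On these data alone, it also remains open whether the same swap would move the number in the same way on the core of compound 3.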